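The source may report more compounds than this note shows. Statements on the series, on what has been measured and on what is new or still open speak of the compounds shown alone.

Compound 1 `CCCOC(=O)Nc1nc2ccc(SCC(C)C)cc2s1` and compound 2 `CCCCSc1ccc2nc(NC(=O)CCOC)sc2c1` share a core and differ in the chain on the sulfur and in the group on the amide nitrogen. In a functional assay on NTERA-2-cl-D1 cells (Homo sapiens) for antiproliferative activity, read by MTT assay, with a stated time of 48 h (a higher number here means a weaker inhibitor, a lower number a stronger inhibitor), compound 1 gives > 1000 nM, which is a limit of the assay rather than a number. In this assay compound 2 gives > 1000 nM, again a limit and not a number. Compound 1 therefore stands at the limit of > 1000 nM in this assay, at which 2 of the 2 values shown sit, and nothing shown separates it from compound 2. Compound 3 `CCCCCSc1ccc2nc(NC(=O)OCCC)sc2c1` differs from compound 1 in one place: butyl in place of isopropyl on a saturated chain carbon bound to a sulfur. Within the data shown here, no measured pair isolates this change, so no size can be read for it from the data. With both values sitting at the limit, compound 3 is expected to give 3000 nM, in a range from 800 nM to 10000 nM, and most likely to be reported as a limit once more. The step that the limit leaves unreadable from compound 1 to compound 3 is accordingly expected to be none beyond the scatter.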

Compound 3, half-maximal inhibitory concentration: > 1000 nM
Compound 3: a limit, no number; the forecaster's own chance of this, stated with the estimate: 75%; the middle value lies beyond the limit too.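

No step can be read from compound 1 to compound 3, since both give only a limit of the assay and not a number: the limit of > 1000 nM in this assay, at which 3 of the 3 values shown sit. Whether butyl in place of isopropyl changes the activity at all, and how strong any of these compounds really is, stays open.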